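The source may report more compounds than this note shows. Statements on the series, on what has been measured and on what is new or still open speak of the compounds shown alone.

Measured in a functional assay on MDA-MB-231 cells (Homo sapiens) for inhibition, read by sulforhodamine B assay, with a stated time of 48 h; on this read-out lower numbers stand for stronger inhibition of growth and higher numbers for weaker inhibition of growth:
- Compound 1 `Cc1nnc(-c2nn(-c3ccccc3)c(-c3ccccc3)c2C#N)c2cn(-c3ccccc3)nc12`: > 100000 nM (a limit of the assay, not a number)
- Compound 2 `N#Cc1c(-c2nnc(O)c3nn(-c4ccccc4)cc23)nn(-c2ccccc2)c1-c1ccccc1`: 6210 nM
- Compound 3 `N#Cc1c(-c2nnc(-c3ccccc3)c3nn(-c4ccccc4)cc23)nn(-c2ccccc2)c1-c1ccccc1`: 8840 nM

Compound 3 stands level with compound 2 on these numbers, as the measured step shows: a 1.4-fold higher number from compound 2 to compound 3 (0.15 log units; within the scatter). Both have real values, whereas compound 1 reached only a limit.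

The next compound is compound 4 `Cc1ccc(-n2cc3c(-c4nn(-c5ccccc5)c(-c5ccccc5)c4C#N)nnc(-c4ccccc4)c3n2)cc1`, which differs from compound 3 by one small change: methyl in place of hydrogen on an aromatic carbon. This is methyl in place of hydrogen on an aromatic carbon, so a phenyl becomes 4-methylphenyl.

Among the measured compounds shown here, no measured step touches this phenyl. All three exchange a different group on an aromatic carbon, so they bear on the change only indirectly. Two of them were large: an at least 16-fold lower number from compound 1 to compound 2 (1.20 log units; beyond the scatter), and an at least 11-fold lower number from compound 1 to compound 3 (1.05 log units; beyond the scatter). The third stayed within the scatter: a 1.4-fold higher number from compound 2 to compound 3 (0.15 log units; within the scatter). Those two large steps show that a single exchange can matter a great deal in this set, so the expectation must stay loose.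

With no measured guide for this methyl, the starting point is compound 3 at 8840 nM, and no step beyond the scatter is expected. The expected step is a 1.1-fold lower number from compound 3 to compound 4 (0.04 log units; within the scatter). For compound 4 the estimated value is 8000 nM, with an expected range from 3000 nM to 25000 nM.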

Compound 4, concentration for 50% growth inhibition: 52100 nM
For compound 4 the middle estimate is 6.5-fold (0.81 log units) below the measured one; measured number above the stated range.
By their numbers in this assay, from the lowest: compounds 2 and 3 (each within the scatter of the next); then compound 4. At a limit, above all of these: compound 1.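

In this assay, the phenyl that becomes 4-methylphenyl proves sensitive to change, since this single methyl gives a 5.9-fold higher number from compound 3 to compound 4 (0.77 log units; beyond the scatter). Among the compounds shown here, no earlier step touched this phenyl, as those steps exchanged groups on a different aromatic carbon, so this is the first sign that one added carbon here moves the number toward weaker inhibition of growth. Compound 4 still gives a real number, so this step can be read in full, and only compound 1 rests on a limit of the assay: the limit of > 100000 nM in this assay, at which 1 of the 4 values shown sits.

What the compounds shown leave open is whether this loss belongs to the methyl itself or would follow any group placed here, and a chlorine atom, a methoxy group, an amine or a carboxylic acid in the same place would begin to separate those two readings. From the compounds shown here alone, it also remains open why the number rises, and whether the same methyl would act in the same way on compound 2, which carries hydroxy where compound 3 carries phenyl.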